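Replacing thiophen-2-yl with 4-methoxyphenyl on a pyridazinone series

The source may hold more compounds than are shown below. What is called first, only, known or untested is meant among the compounds shown, and "the series" means these compounds.

Compound 1 `COc1cccc(Cc2cc(-c3ccccc3)nn(CC(=O)Nc3ccc(F)cc3)c2=O)c1` — > 50000 nM
Compound 2 `COc1ccc(Cc2cc(-c3cccs3)nn(CC(=O)Nc3ccc(Br)cc3)c2=O)cc1` — > 50000 nM
Compound 3 `COc1cccc(Cc2cc(-c3cccs3)nn(CC(=O)Nc3ccc(F)cc3)c2=O)c1` — > 50000 nM

In an assay on HL-60 cells for agonist activity at N-formyl peptide receptor 3 (Homo sapiens), read by calcium flux (a higher number here means that more compound is needed for the effect, a lower number that less compound is needed), compound 2 gives only a limit of the assay, > 50000 nM. Compound 1 likewise gives only a limit, > 50000 nM, in this assay. Compound 3 also returns only a limit, > 50000 nM. All three values thus sit at the limit of > 50000 nM in this assay, at which 3 of the 3 values shown sit, and no numerical potency is known for any of them. Going by the values given here, the one change measured within the set, a step that the two limits leave unreadable from compound 1 to compound 3, cannot be read for size because both ends are limits.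

Compound 4 `COc1ccc(Cc2cc(-c3ccc(OC)cc3)nn(CC(=O)Nc3ccc(Br)cc3)c2=O)cc1` differs from compound 2 by 4-methoxyphenyl in place of thiophen-2-yl on an aromatic carbon next to the ring nitrogen. Among the compounds with values here, no measured step bears on this change, so no direction beyond the scatter can be expected for it in this assay. Given that compound 2 sits at the limit, compound 4 is estimated at 60000 nM, within a range from 15000 nM to 250000 nM, most likely again reported only as a limit. That estimate corresponds to an expected step that the limit leaves unreadable from compound 2 to compound 4.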

Compound 4, half-maximal effective concentration: > 50000 nM
Compound 4 ended at the assay's limit (the forecaster's own chance of this, stated with the estimate: 80%); the middle value is on the limit's open side.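

In this assay compound 4 gives only a limit, > 50000 nM. Compound 2 also gives only a limit, > 50000 nM, so no step can be read between compound 2 and compound 4. The compounds shown leave open whether 4-methoxyphenyl and thiophen-2-yl differ at all, and what potency any compound has: the limit of > 50000 nM in this assay, at which 4 of the 4 values shown sit.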